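Hydroxy for Amino on Two Fluorinated Cores

A few compounds are considered here, and "the series" means these few. Any claim that something is new, unique, unknown or untested is made for them only; others in the source may bear on it.

This account concerns four compounds tested in a functional assay on CCRF-CEM cells (Homo sapiens) for cytotoxicity; a lower number here means a stronger inhibitor, a higher number a weaker inhibitor. Compound 1 `Nc1ccn([C@@H]2C=C(F)[C@H](CO)O2)c(=O)n1` carries an amino group on the core. In this assay compound 1 gives only a limit, > 100000 nM. Compound 2 `O=c1nc(O)ccn1[C@@H]1C=C(F)[C@H](CO)O1` differs by hydroxy in place of amino on an aromatic carbon. In this assay compound 2 gives 30100 nM. That is an at least 3.3-fold lower number from compound 1 to compound 2 (0.52 log units; beyond the scatter); the size of the step is bounded only because of the limit of > 100000 nM in this assay, at which 2 of the 3 values shown sit.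

Compound 3 `Nc1ncnc2c1ncn2[C@@H]1CC(F)(F)[C@H](CO)O1` has a different core; the difference between the two cores is not broken down here. In this assay compound 3 gives only a limit, > 100000 nM. Compound 4 `OC[C@@H]1O[C@H](n2cnc3c(O)ncnc32)CC1(F)F` differs from compound 3 by hydroxy in place of amino on an aromatic carbon. This is the same kind of change as from compound 1 to compound 2, though the place differs: in compound 4 the ring is part of a fused or bridged system of two rings, ortho to a fused ring and meta to a fused ring, whereas in compound 2 it is meta to a group of 1 heavy atom and para to a group of 8 heavy atoms.

On the strength of compound 2 and an at least 3.3-fold lower number from compound 1 to compound 2 (0.52 log units; beyond the scatter), compound 4 is expected to show a number no higher from compound 3 to compound 4 (the limit leaves the size open). Compound 4 is therefore estimated at 100000 nM, between 30000 nM and 400000 nM.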

Compound 4, half-maximal inhibitory concentration: > 100000 nM
Compound 4 ended at the assay's limit; the forecaster's own chance of this, stated with the estimate: 60%; the middle value lies on the limit itself.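

In this assay compound 4 gives only a limit, > 100000 nM. Compound 3 is also only a limit, so no step can be read between compound 3 and compound 4: the limit of > 100000 nM in this assay, at which 3 of the 4 values shown sit. The compounds shown leave open whether hydroxy in place of amino lowers the number on the core of compound 3, as it does on the core of compound 1.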